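The compounds below may be only part of what the source reports. "The series", "measured", "known", "first", "only" and "open" are said of these compounds alone.

Measured compounds in an in vitro assay on HEK385-7 cells for displacement of a labelled ligand from prostaglandin D2 receptor 2 (Homo sapiens); on this read-out higher numbers stand for weaker inhibition and lower numbers for stronger inhibition:
Compound 1, `O=C(O)Cc1sc(C(c2ccccc2)c2ccc(F)cc2)nc1-c1ccc(Cl)cc1`: compound 1 gives 17 nM.
Compound 2, `O=C(O)Cc1sc(C(c2ccc(F)cc2)c2ccc(F)cc2)nc1-c1ccc(Cl)cc1`: compound 2 gives 9.7 nM.
Compound 3, `O=C(O)Cc1sc(C(c2ccccc2)c2ccccn2)nc1-c1ccc(Cl)cc1`: compound 3 gives 810 nM.

Compound 2 has the lowest of the three numbers, but its gap to compound 1, a 1.8-fold lower number from compound 1 to compound 2 (0.24 log units; within the scatter), lies within the scatter, so the two cannot be ordered. Compound 3 stands far apart, as the step of a 48-fold higher number from compound 1 to compound 3 (1.68 log units; beyond the scatter) shows.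

Compound 4, `NS(=O)(=O)c1cccc(-c2nc(C(c3ccc(F)cc3)c3ccc(F)cc3)sc2CC(=O)O)c1`, differs from compound 2 in one place: 3-sulfamoylphenyl in place of 4-chlorophenyl on an aromatic carbon. Neither measured step touches this position. The step from compound 1 to compound 2 concerns a fluoro on the diaryl carbon, and the step from compound 1 to compound 3 concerns a pyridin-2-yl there; both leave the 4-chlorophenyl untouched. No measured change therefore bears on the present one, and the direction of its effect in this assay cannot be read from the data. The estimate for compound 4 is 30 nM, with a range from 5 nM to 200 nM, meaning an expected step of a 3.1-fold higher number from compound 2 to compound 4 (0.49 log units; beyond the scatter).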

Compound 4, half-maximal inhibitory concentration: 140 nM
Estimate against measurement, compound 4: 4.7-fold (0.67 log units) below; the range from low to high includes it.
By their numbers in this assay, from the lowest: compounds 2 and 1 (each within the scatter of the next); then compound 4; then compound 3.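

Among these compounds, the aromatic carbon next to the ring nitrogen, untouched by the earlier steps, turns out to be sensitive in this assay: 3-sulfamoylphenyl in place of 4-chlorophenyl gives a 14-fold higher number from compound 2 to compound 4 (1.16 log units; beyond the scatter), a large step beyond the scatter. The position is therefore not indifferent to what it carries, although the change does not abolish displacement, as compound 4 still gives 140 nM. The data offer no measured explanation for this loss of inhibition.

Since the chlorine leaves and the sulfamoyl group enters in a single change, the compounds shown do not separate the effect of losing the one from that of gaining the other. A plain phenyl at this position would address that question, while an amine or a carboxylic acid in place of the sulfamoyl group would show whether other groups on this phenyl ring fare differently.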